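Swapping the Aryl Group on a Shared Amine Nitrogen

This account rests on a few compounds, and the source may have more. Where it says the series, first, only, none or still open, it means among the compounds named here.

Compound 1 `O=C1C=C(Nc2ccc(I)cc2)C(=O)c2c1nc1n2[C@H]2OC[C@@H](O)[C@H]2OC1`: 4070 nM
Compound 2 `O=C1C(Nc2cccc(Cl)c2)=CC(=O)c2c1nc1n2[C@H]2OC[C@@H](O)[C@H]2OC1`: 7970 nM

Of the compounds shown here, two have been measured in a functional assay on HeLa cells (Homo sapiens) for inhibition, read by sulforhodamine B assay; on this read-out higher numbers stand for weaker inhibition and lower numbers for stronger inhibition. Compound 1 gives 4070 nM, and compound 2 gives 7970 nM. Compound 2 carries the higher of the two numbers, but the gap to compound 1 falls within the usual scatter of this assay, so the two compounds cannot be told apart on these data.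

Compound 3 `COc1ccc(NC2=CC(=O)c3c(nc4n3[C@H]3OC[C@@H](O)[C@H]3OC4)C2=O)cc1` has not yet been measured. It differs from compound 2 in one place:

4-methoxyphenyl in place of 3-chlorophenyl on an amine nitrogen

Going by the values given here, no pair of measured compounds shares this change, so there is no measured step to lean on. Among the compounds with values here, with only the single value of compound 2 available, the expectation for compound 3 is a step of a 1.0-fold higher number from compound 2 to compound 3 (0.00 log units; within the scatter) in this assay, that is, no change beyond the scatter in either direction. On that basis compound 3 is estimated to give 8000 nM in this assay, with a plausible range from 3000 nM to 22000 nM.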

Compound 3, half-maximal inhibitory concentration: > 8000 nM
Compound 3 was reported as a limit; the forecaster's own chance of this, stated with the estimate: 10%; the middle value lies on the limit itself.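

In this assay compound 3 is reported as a limit, > 8000 nM, not as an exact number. Its size cannot be read, but the step does have a direction: on this amine nitrogen, 4-methoxyphenyl in place of 3-chlorophenyl gives a number no lower from compound 2 to compound 3 (the limit leaves the size open), so this swap brings no stronger inhibition in this assay. How far the number rises stays unknown because the reading stops at a limit: the limit of > 8000 nM in this assay, at which 1 of the 3 values shown sits.

The compounds shown leave open how far compound 3 lies past its limit, and so whether the change makes any real difference or a large one. They also leave open what other groups on this nitrogen would do, for example a plain phenyl without any substituent, a phenyl ring bearing a carboxylic acid, or a short alkyl chain in place of the aromatic ring.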